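Urea Partner Swap Where Every Measurement Is a Limit

A few compounds are considered here, and "the series" means these few. Any claim that something is new, unique, unknown or untested is made for them only; others in the source may bear on it.

Compound 3 `COC(=O)c1cc(=O)c2cc(NC(=O)Nc3ccc(Cl)c(Cl)c3)ccc2[nH]1` carries a urea with a 3,4-dichlorophenyl group on a shared core. In a functional assay on KOPN-8 cells (Homo sapiens) for antiproliferative activity, with a stated time of 72 h (a lower number here means that less compound is needed, a higher number that more compound is needed for the effect), compound 3 gives only a limit, > 6350 nM. Compound 2 `COC(=O)c1cc(=O)c2cc(NC(=O)Nc3ccc(Cl)c(C(F)(F)F)c3)ccc2[nH]1` has trifluoromethyl where compound 3 has chloro. In this assay compound 2 also stops at a limit, > 6350 nM. The step that the two limits leave unreadable from compound 2 to compound 3 is therefore unreadable. Compound 1 `COc1ccc(-c2cc(=O)c3c(OC)cc(OC)cc3n2S(=O)(=O)c2cc(F)c(F)c(F)c2)cc1`, built on a different core, likewise reaches only a limit in this assay, > 65500 nM. Every value shown is thus a limit, two at the limit of > 6350 nM in this assay, at which 2 of the 3 values shown sit, and one at the limit of > 65500 nM in this assay, at which 1 of the 3 values shown sits.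

Compound 4 `COC(=O)c1cc(=O)c2cc(NC(=O)Nc3cccc(C(C)=O)c3)ccc2[nH]1` has not been measured. The change from compound 3 is 3-acetylphenyl in place of 3,4-dichlorophenyl on an amide-type nitrogen. Among the measured compounds shown here, no measured step bears on this change, since the only step, a step that the two limits leave unreadable from compound 2 to compound 3, cannot be read. With nothing measurable among the three compounds, the expectation is that this assay again reports no number for compound 4. The step that the limit leaves unreadable from compound 3 to compound 4 that this estimate means is expected to stay hidden beneath the limit. The estimate for compound 4 is 12000 nM, expected to lie between 3000 nM and 50000 nM.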

Compound 4, half-maximal effective concentration: > 8080 nM
Compound 4: only a limit was reported (the forecaster's own chance of this, stated with the estimate: 80%); the middle value does not contradict the limit.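

In this assay compound 4 gives only a limit, > 8080 nM. Compound 3 also gives only a limit, so the step from compound 3 to compound 4 cannot be read. Still open, going by these compounds, is whether changing the urea partner alters the concentration needed for the effect.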